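Swapping a thiophene for a fluorophenyl on the ketone

The source may report more compounds than this note shows. Statements on the series, on what has been measured and on what is new or still open speak of the compounds shown alone.

Compound 2 `COc1cc(-c2nnc3n2NC(c2ccco2)C(C(=O)c2cccs2)S3)cc(OC)c1OC` carries a thiophen-2-yl group on its carbonyl carbon. In a functional assay on MCF7 cells (Homo sapiens) for cytotoxicity, read by MTT assay, with a stated time of 48 h (on this read-out higher numbers stand for weaker inhibition and lower numbers for stronger inhibition), compound 2 reaches only a limit of the assay, > 100000 nM. That value sits at the limit of > 100000 nM in this assay, at which 1 of the 2 values shown sits. Its closest measured neighbour is compound 1 `COc1cc(-c2nnc3n2NC(c2ccco2)C(C(=O)c2ccccc2F)S3)cc(OC)c1OC`, which differs only by a 2-fluorophenyl in the same place; in this assay compound 1 gives 94800 nM. The step of an at least 1.0-fold higher number from compound 1 to compound 2 (0.02 log units; that floor lies within the scatter) thus shows no change beyond the scatter. Compound 3 `COc1cc(-c2nnc3n2NC(c2ccco2)C(C(=O)c2ccc(F)cc2)S3)cc(OC)c1OC` is not yet measured. It differs from compound 2 by 4-fluorophenyl in place of thiophen-2-yl on a carbonyl carbon. Among the measured compounds shown here, the only measured step at this position, from a fluorophenyl to the thiophene, stayed within the scatter, so a return to a fluorophenyl is expected to move the number little. Compound 3 is therefore expected to lie near the measured pair, with a step of a number no higher from compound 2 to compound 3 (the limit leaves the size open) that stays within the scatter. The estimate for compound 3 in this assay is 100000 nM, ranging from 40000 nM to 250000 nM, with a fair chance that only a limit is reported again.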

Compound 3, half-maximal inhibitory concentration: > 100000 nM
Compound 3 was reported as a limit; the forecaster's own chance of this, stated with the estimate: 55%; the middle value sits exactly at the limit.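

In this assay compound 3 also gives only a limit of the assay, > 100000 nM. The 4-fluorophenyl in place of the 2-fluorophenyl gives an at least 1.0-fold higher number from compound 1 to compound 3 (0.02 log units; that floor lies within the scatter), so a second change at this carbonyl carbon shows no shift beyond the scatter, while the step between the two compounds that both sit at the limit cannot be read. With three different groups in this place, the data now show no group that gives a number clearly lower than the others, and most of the values stand at the limit: the limit of > 100000 nM in this assay, at which 2 of the 3 values shown sit.

The compounds shown leave open whether a 4-aminophenyl or a 4-carboxyphenyl on this carbonyl carbon would give a clearly lower number. They also leave open whether a change elsewhere on the shared core would do more than a change here.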